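The source may report more compounds than this note shows. Statements on the series, on what has been measured and on what is new or still open speak of the compounds shown alone.

Measured so far in a functional assay on HeLa cells (Homo sapiens) for inhibition, read by MTT assay, with a stated time of 48 h; a lower number here means a stronger inhibitor, a higher number a weaker inhibitor:
compound 2 `COc1ccc2c(=O)c(/C=C/C(=O)Nc3ccccc3C)coc2c1` — 7270 nM
compound 1 `COc1ccc(CNC(=O)/C=C/c2coc3cc(OC)ccc3c2=O)cc1` — a limit of the assay, > 100000 nM

Within the data shown here, compound 2 holds the only number in this assay; the other value is a limit, (the limit of > 100000 nM in this assay, at which 1 of the 2 values shown sits). Compound 3 `COc1ccc2c(=O)c(/C=C/C(=O)Nc3ccc(Cl)cc3)coc2c1` differs from compound 2 by 4-chlorophenyl in place of 2-methylphenyl on an amide-type nitrogen. Among the measured compounds shown here, the single measured step, an at least 13-fold lower number from compound 1 to compound 2 (1.13 log units; beyond the scatter), exchanged a benzyl for an aryl on the same nitrogen and does not speak to an aryl-to-aryl exchange. For the measured compounds named here, no measured step therefore sets the size. For compound 3 the expected step in this assay is a 1.1-fold lower number from compound 2 to compound 3 (0.05 log units; within the scatter), nothing beyond the scatter. Compound 3 is estimated at 6500 nM, within 2000 nM to 25000 nM.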

Compound 3, half-maximal inhibitory concentration: > 100000 nM
Compound 3: only a limit was reported (the forecaster's own chance of this, stated with the estimate: 10%); at least 15-fold (1.18 log units) between middle value and limit.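

In this assay, one aryl group cannot simply replace another on the amide-type nitrogen: 4-chlorophenyl in place of 2-methylphenyl gives an at least 13-fold higher number from compound 2 to compound 3 (1.13 log units; beyond the scatter). The earlier step covered only a benzyl-to-aryl exchange; this one shows that an aryl on this nitrogen is not enough by itself, as compound 2 alone of the three has a measured number. The step from compound 1 to compound 3 cannot be read, as both values are limits: the limit of > 100000 nM in this assay, at which 2 of the 3 values shown sit.

From the compounds shown here alone, whether the chlorine or the absence of the methyl drives this step stays open. A 2-chlorophenyl or 4-methylphenyl group on the same nitrogen would separate the two.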